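Fluoro for Hydroxy: What to Expect in Cells

The source may report more compounds than this note shows. Statements on the series, on what has been measured and on what is new or still open speak of the compounds shown alone.

Two compounds have been measured in a functional assay on PC-3 cells (Homo sapiens) for inhibition; a higher number here means a weaker inhibitor, a lower number a stronger inhibitor:

Compound 1 `Cc1c(C(=O)N/N=C\c2ccccc2C(F)(F)F)oc2cccc(O)c12`: 26200 nM
Compound 2 `Cc1c(C(=O)N/N=C\c2cc(O)ccc2O)oc2cccc(O)c12`: 95500 nM

Compound 2 gives the higher of these two numbers, and compound 1 the lower one, a gap beyond the usual scatter. Compound 3 `Cc1c(C(=O)N/N=C\c2cc(F)ccc2O)oc2cccc(O)c12` differs from compound 2 in one place: fluoro in place of hydroxy on an aromatic carbon. For the measured compounds named here, no step between measured compounds covers this change, so the expectation rests on the two values alone. Compound 3 is expected to come out somewhat stronger than compound 2, a step of a 2.4-fold lower number from compound 2 to compound 3 (0.38 log units; beyond the scatter), modest and not certain to exceed the scatter. The estimate for compound 3 is 40000 nM, within 15000 nM to 120000 nM.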

Compound 3, half-maximal inhibitory concentration: 3170 nM
Beside the measured number, compound 3's estimate is 13-fold (1.10 log units) above it, and the stated range ends above it.
By their numbers in this assay, from the lowest: compound 3; then compound 1; then compound 2.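

In this assay this position turns out to be far more sensitive than the first two compounds could reveal: going from 2,5-dihydroxyphenyl to 5-fluoro-2-hydroxyphenyl gives a 30-fold lower number from compound 2 to compound 3 (1.48 log units; beyond the scatter), a large change for the exchange of a single heavy atom. Nothing shown here accounts for a step of this size.

From the compounds shown here alone, it remains open whether fluoro is special at this place or whether chloro, methoxy or an amine would give a similar result. This single pair also cannot show whether the step would hold with other groups elsewhere on the molecule.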